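Three aryl-thiophene ketones and a biphenyl analogue awaiting measurement

The source may report more compounds than this note shows. Statements on the series, on what has been measured and on what is new or still open speak of the compounds shown alone.

Measured so far in a functional assay on MOLT-4 cells (Homo sapiens) for antiproliferative activity; a lower number here means a stronger inhibitor, a higher number a weaker inhibitor:
Compound 1, `COc1cc(C(=O)c2sc(-c3ccc(F)cc3)cc2N)cc(OC)c1OC`, gives 12 nM.
Compound 2, `COc1cc(C(=O)c2sc(-c3cccc([N+](=O)[O-])c3)cc2N)cc(OC)c1OC`, gives 7.5 nM.
Compound 3, `COc1cc(C(=O)c2sc(-c3ccncc3)cc2N)cc(OC)c1OC`, gives 88 nM.

All three share the same core and differ only in the aromatic group attached to it. Compound 1 stands second highest of the three numbers: its nearest neighbour is compound 2, reached by a 1.6-fold lower number from compound 1 to compound 2 (0.20 log units; within the scatter), and its furthest is compound 3, reached by a 7.3-fold higher number from compound 1 to compound 3 (0.87 log units; beyond the scatter). Compound 2 and compound 3 are separated by a 12-fold higher number from compound 2 to compound 3 (1.07 log units; beyond the scatter).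

Compound 4, `COc1cc(C(=O)c2sc(-c3ccc(-c4ccccc4)cc3)cc2N)cc(OC)c1OC`, is not yet measured. It differs from compound 1 in one place: phenyl in place of fluoro on an aromatic carbon. For the measured compounds named here, none of the measured steps replaces the fluoro with another ring; the steps so far swap the whole aromatic group, and they show that the carbocyclic groups of compound 1 and compound 2 sit close together while the pyridin-4-yl of compound 3 gives a clearly higher number. A phenyl entering where a fluoro leaves keeps the attached ring carbocyclic, so a modest change in this assay is expected, with the direction uncertain but leaning toward a higher number. The estimated step from compound 1 to compound 4 is a 2.5-fold higher number from compound 1 to compound 4 (0.40 log units; beyond the scatter). Compound 4 is therefore expected to give about 30 nM, within a range from 6 nM to 150 nM.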

Compound 4, half-maximal inhibitory concentration: > 10000 nM
Compound 4: only a limit was reported (the forecaster's own chance of this, stated with the estimate: 5%); at least 330-fold (2.52 log units) between middle value and limit.
By their numbers in this assay, from the lowest: compounds 2 and 1 (each within the scatter of the next); then compound 3. At a limit, above all of these: compound 4.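

In this assay compound 4 gives > 10000 nM, which is a limit of the assay and not a number. The earlier steps shown here exchanged the whole aromatic group, whereas this one keeps the attached ring and changes only what it carries on an aromatic carbon, para to a large group: phenyl in place of fluoro gives an at least 830-fold higher number from compound 1 to compound 4 (2.92 log units; beyond the scatter), a far larger step than any seen among compounds 1, 2 and 3, so a carbocyclic ring attached to the shared core does not by itself preserve activity, and this single place can decide between low-nanomolar activity and none detectable here. Compound 4 is the only one of the four at such a limit: the limit of > 10000 nM in this assay, at which 1 of the 4 values shown sits.

The compounds shown leave open where between fluoro and phenyl the loss sets in, since a methyl, a methoxy, a chlorine or a short alkyl chain in the same place would fill in that range. They also cannot tell why the second ring has this effect, or whether a ring such as pyridine or a saturated cyclohexyl in its stead would behave the same way.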